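Swapping a Saturated Ring for an Aromatic One

This account rests on a few compounds, and the source may have more. Where it says the series, first, only, none or still open, it means among the compounds named here.

Of the compounds shown here, three that share one core have been measured in an assay on HeLa cells for binding affinity to Vasopressin V2 receptor (Homo sapiens); on this read-out lower numbers stand for stronger inhibition and higher numbers for weaker inhibition. Compound 1 `CCCCNc1ccc(C(=O)N2CCCCc3ccccc32)c(Cl)c1` gives 22 nM. Compound 2 `C=CCNc1ccc(C(=O)N2CCCCc3ccccc32)c(Cl)c1` gives 5.9 nM, and compound 3 `O=C(c1ccc(N2CCCC2)cc1Cl)N1CCCCc2ccccc21` gives 9 nM. Among these three numbers compound 3 holds the second highest; compound 2 is its nearest neighbour, and the two lie within the scatter of each other, while the gap to compound 1 lies beyond it. Compound 4 `Cc1ccn(-c2ccc(C(=O)N3CCCCc4ccccc43)c(Cl)c2)n1` carries 3-methyl-1H-pyrazol-1-yl in place of pyrrolidin-1-yl on an aromatic carbon. Within the data shown here, the change sits at the same aromatic carbon that was varied in the earlier steps: the step of a 2.4-fold lower number from compound 1 to compound 3 (0.39 log units; beyond the scatter) was modest, and the step of a 1.5-fold higher number from compound 2 to compound 3 (0.18 log units; within the scatter) stayed within the scatter. Neither of those earlier changes brought in an aromatic ring, so the measured data give little guidance on direction. A step of about a 1.7-fold higher number from compound 3 to compound 4 (0.22 log units; within the scatter) is therefore expected, meaning no shift beyond the scatter. Compound 4 is estimated to give 15 nM in this assay, with a plausible range from 4 nM to 60 nM.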

Compound 4, half-maximal inhibitory concentration: 13 nM
Beside the measured number, compound 4's estimate is 1.2-fold (0.06 log units) above it, and the stated range covers the measured number.
By their numbers in this assay, from the lowest: compounds 2, 3, 4 and 1 (each within the scatter of the next, the first and the last beyond it).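

At this aromatic carbon, a five-membered aromatic ring is accepted in this assay: 3-methyl-1H-pyrazol-1-yl in place of pyrrolidin-1-yl gives a 1.4-fold higher number from compound 3 to compound 4 (0.16 log units; within the scatter), so moving from a non-aromatic ring to an aromatic one leaves the number within the scatter. Against the two open chains the result splits, with the allylamino group replaced in a 2.2-fold higher number from compound 2 to compound 4 (0.34 log units; beyond the scatter) and the butylamino group replaced in a 1.7-fold lower number from compound 1 to compound 4 (0.23 log units; within the scatter). No measurement at hand explains why the aromatic ring is accepted here.

As far as these compounds go, the part played by the methyl group on the pyrazole ring remains open, as does whether a phenyl, pyridine or imidazole ring at this carbon would behave the same way. A carboxylic acid or a primary amine at this position is also unexplored territory in the compounds shown.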